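The source may report more compounds than this note shows. Statements on the series, on what has been measured and on what is new or still open speak of the compounds shown alone.

Notes on the series. Compound 1 `COC(=O)/C=C/c1cccc(N(Cc2ccc(/C=C/c3ccccc3F)cc2)C(=O)C2CCCCC2)c1` carries a 2-fluorophenyl on a double-bonded chain carbon bound to a double-bonded chain carbon; in an assay on isolated protein with Bile acid receptor (Homo sapiens) as the target (on this read-out higher numbers stand for an effect only at larger amounts of compound and lower numbers for an effect already at smaller amounts), compound 1 gives 64 nM. Compound 2 `COC(=O)/C=C/c1cccc(N(Cc2ccc(/C=C/C(=O)OCc3ccccc3)cc2)C(=O)C2CCCCC2)c1` carries a benzyloxycarbonyl in that place. In this assay compound 2 reaches only the limit > 1000 nM, so no number is known for it. For the measured compounds named here, the one measured step, an at least 15-fold higher number from compound 1 to compound 2 (1.19 log units; beyond the scatter), is the sole point of reference; it rests on (the limit of > 1000 nM in this assay, at which 1 of the 2 values shown sits), so its true size is not fixed. Compound 3 `COC(=O)/C=C/c1cccc(N(Cc2ccc(/C=C/c3ccc(F)cc3)cc2)C(=O)C2CCCCC2)c1` is the next member. The change from compound 2 is 4-fluorophenyl in place of benzyloxycarbonyl on a double-bonded chain carbon bound to a double-bonded chain carbon. This change undoes the group swap that produced the large step from compound 1 to compound 2, exchanging the benzyloxycarbonyl for a fluorophenyl once more. A large drop in this assay is therefore expected, an at least 11-fold lower number from compound 2 to compound 3 (1.04 log units; beyond the scatter). For compound 3 the estimate in this assay is 90 nM, within 30 nM to 300 nM, close to the value of compound 1 64 nM.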

Compound 3, half-maximal effective concentration: 185 nM
Beside the measured number, compound 3's estimate is 2.1-fold (0.31 log units) below it; low and high end bracket the measured number.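

Replacing the benzyloxycarbonyl with 4-fluorophenyl on a double-bonded chain carbon bound to a double-bonded chain carbon restores a measurable number in this assay, with an at least 5.4-fold lower number from compound 2 to compound 3 (0.73 log units; beyond the scatter). The true size of this step is not fixed: the limit of > 1000 nM in this assay, at which 1 of the 3 values shown sits. For the compounds shown here, the place of the fluorine on the phenyl can now be read for the first time, as 4-fluorophenyl in place of 2-fluorophenyl gives a 2.9-fold higher number from compound 1 to compound 3 (0.46 log units; beyond the scatter).

From the compounds shown here alone, how an unsubstituted phenyl or a chlorophenyl in this place would stand against the two fluorophenyl compounds remains open. Also open, going by these compounds, is whether the large number for compound 2 goes with the benzyloxycarbonyl as a whole or with its carbonyl, a question that a carboxylic acid or a benzyl ether in the same place would help to separate.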